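The source may hold more compounds than are shown below. What is called first, only, known or untested is meant among the compounds shown, and "the series" means these compounds.

Compound 1 `CC(C)(C)[C@@H](O)C(=O)N1CSC[C@H]1C(=O)NCc1cc(Cl)ccc1-n1cnnn1`: 19 10^-6 cm/s
Compound 2 `CC1(C[C@@H](O)C(=O)N2C[C@H]3C[C@H]3[C@H]2C(=O)NCc2cc(Cl)ccc2-n2cnnn2)CC1`: 2.2 10^-6 cm/s
Compound 3 `O=C(NCc1cc(Cl)ccc1-n1cnnn1)[C@@H]1CC=NN1C(=O)[C@H](O)c1ccccc1`: 7 10^-6 cm/s

Of the compounds shown here, three have been measured in an ADME assay on Caco-2 cells (Homo sapiens) for permeability, read by LC-MS, in the apical to basolateral direction, with a stated time of 60 min, at pH 6.5; on this read-out higher numbers stand for higher permeability and lower numbers for lower permeability. Compound 2 stands lowest of the three numbers; compound 3 is the nearest to it and lies beyond the scatter above it, while compound 1 lies furthest above it. Within the data shown here, no two measured compounds differ in only one place, so no single step can be read from them. Compound 4 `CC(C)(C)[C@@H](O)C(=O)N1C[C@H]2C[C@H]2[C@H]1C(=O)NCc1cc(Cl)ccc1-n1cnnn1` is not yet measured. It differs from compound 2 in one place: tert-butyl in place of (1-methylcyclopropyl)methyl on a saturated chain carbon bound to a carbonyl carbon and an oxygen on a saturated carbon. Compound 1 also carries a tert-butyl here and gives 19 10^-6 cm/s, though it differs from compound 2 in its core as well. Compound 4 is therefore expected to move upward modestly, by a 2.0-fold higher number from compound 2 to compound 4 (0.31 log units; beyond the scatter), a step that may or may not clear the scatter. The estimate for compound 4 is 4.5 10^-6 cm/s, with a range from 1.5 10^-6 cm/s to 12 10^-6 cm/s.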

Compound 4, apparent permeability: 3.8 10^-6 cm/s
The estimate for compound 4 lay 1.2-fold (0.07 log units) above the measured number, within the range that was stated.
By their numbers in this assay, from the lowest: compounds 2, 4 and 3 (each within the scatter of the next, the first and the last beyond it); then compound 1.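

In this assay, the first step readable at this position, tert-butyl in place of (1-methylcyclopropyl)methyl, gives a 1.7-fold higher number from compound 2 to compound 4 (0.24 log units; within the scatter). On this shared core, the two groups therefore cannot be told apart on this read-out, even though one carries a three-membered ring and the other has none. No measurement shown offers an explanation for this result.

On these data alone, whether an amine or a carboxylic acid at this position would give a number beyond the scatter remains open. So does whether the same exchange would give a similar step on the core of compound 1.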